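Mirror-Image Urea: From Compound 3 to Compound 4

The source may report more compounds than this note shows. Statements on the series, on what has been measured and on what is new or still open speak of the compounds shown alone.

Compound 1 `Cc1ccccc1NC(=O)N[C@H](C)c1ccccc1` and compound 2 `Cc1ccccc1NC(=O)N[C@@H](C)c1ccccc1` are two ureas that share every atom and bond and differ only in the drawn configuration of a single stereocentre. In an ADME assay on the whole organism with Oryza sativa as the target, tested at 1 uM (on this read-out higher numbers stand for a weaker effect at the one concentration tested and lower numbers for a stronger effect), compound 1 gives 100% and compound 2 gives 99%; the step is a number 1 percentage points lower from compound 1 to compound 2 (within the scatter). Because the fact that compounds 1 and 2 differ only in the configuration as drawn this pair shows that reversing the drawn configuration at this centre leaves the read-out essentially where it was. Compound 3 `Cc1cccc(NC(=O)N[C@H](C)c2ccccc2)c1` is a close relative and gives 98% in this assay, a number that sits within the usual scatter of both compound 1 and compound 2. Compound 4 `Cc1cccc(NC(=O)N[C@@H](C)c2ccccc2)c1` has not yet been measured. Its difference from compound 3 is the two compounds have the same atoms and bonds and differ only in configuration as drawn: 1 of 1 stereo elements differ; a stereocentre at a saturated chain carbon is drawn R in compound 3 and S in compound 4. Among the measured compounds shown here, the only measured step of the same kind, from compound 1 to compound 2, stayed within the scatter, so no change beyond the scatter is expected here either. Compound 4 is therefore estimated at 98%, with a range from 90% to 100%. The expected step is no change at the digits printed from compound 3 to compound 4 (within the scatter).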

Compound 4, a percentage reported as activity, at one concentration (the size of the read-out at that concentration, not a potency): 100%
Estimate against measurement, compound 4: 2 percentage points below; the measured number falls inside the stated range.
By their numbers in this assay, from the lowest: compounds 3, 2, 1 and 4 (each within the scatter of the next).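

In this assay, the second reversal of drawn configuration gives a number 2 percentage points higher from compound 3 to compound 4 (within the scatter). What was a single observation in compounds 1 and 2 now holds in a second pair of ureas, so the lack of a measurable response to reversing this stereocentre no longer rests on one pair alone. This comparison isolates the stereocentre, with no atom or bond changed: the fact that compounds 3 and 4 differ only in the configuration as drawn.

Both mirror-image pairs sit in a narrow band of values, and a single concentration cannot show whether configuration would matter for a urea with a clearly stronger effect. Going by these compounds, whether the two mirror forms would still match with a longer chain at the stereocentre, or with an amine or a carboxylic acid on the shared core, remains open.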